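Rebranching the alkyl chain of compound 2

The source may report more compounds than this note shows. Statements on the series, on what has been measured and on what is new or still open speak of the compounds shown alone.

In a functional assay (aorta) with Rattus norvegicus as the target (a higher number here means a weaker inhibitor, a lower number a stronger inhibitor), compound 1 (`CC(C)CC/N=C(\NC#N)Nc1cc(C(F)(F)F)cc(C(F)(F)F)c1`) gives 5600 nM and compound 2 (`CC(C)CC/N=C(\NC#N)Nc1cc(Cl)cc(Cl)c1`) gives 18700 nM as its reading, so compound 2 holds the higher number of the two, clearly beyond the scatter. Compound 3 (`CCC(C)(C)/N=C(\NC#N)Nc1cc(Cl)cc(Cl)c1`) keeps the core of compound 2 but carries 1,1-dimethylpropyl in place of isopentyl on a double-bonded nitrogen. Going by the values given here, no measured pair shows this swap, so any forecast is loose. A downward move beyond the scatter is expected, an estimated step of a 3.1-fold lower number from compound 2 to compound 3 (0.49 log units; beyond the scatter) in this assay toward a stronger inhibitor. Compound 3 is expected to read 6000 nM (estimated range 1500 nM to 22000 nM).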

Compound 3, half-maximal inhibitory concentration: 300 nM
Compound 3: middle estimate off by 20-fold (1.30 log units), on the high side, outside the stated range (below it).
By their numbers in this assay, from the lowest: compound 3; then compound 1; then compound 2.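

In this assay, putting 1,1-dimethylpropyl in place of isopentyl on the double-bonded nitrogen gives a 62-fold lower number from compound 2 to compound 3 (1.79 log units; beyond the scatter) with the same count of carbon atoms. Compound 1 and compound 2 both carry isopentyl, so they said nothing about this position. This step shows that the way the chain branches, with its carbon count unchanged, can strongly change the reading here. As far as these compounds go, whether a tert-butyl or cyclohexyl group would do the same at this place remains open, as does whether 1,1-dimethylpropyl would give a similar step on the core of compound 1. Nothing measured here explains the size of this step.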